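Moving a fluorine on the aniline ring of compound 3

This account rests on a few compounds, and the source may have more. Where it says the series, first, only, none or still open, it means among the compounds named here.

Of the compounds shown here, three sharing one core have been measured in an assay on HEK293 cells for antagonist activity at transient receptor potential M8 protein (Canis lupus familiaris), read by fluorescence and calcium flux, with a stated time of 5 min; on this read-out lower numbers stand for stronger inhibition and higher numbers for weaker inhibition. Compound 1 `O=C(C(Nc1ccccc1F)c1ccc(C(F)(F)F)cc1)N1CCCC1c1cccc(F)c1` gives 9 nM, compound 2 `O=C(C(Nc1ccccc1F)c1ccc(C(F)(F)F)cc1)N1CCCC1c1ccc(F)cc1` gives 37 nM, and compound 3 `O=C(C(Nc1ccccc1F)c1ccc(C(F)(F)F)cc1)N1CCCC1c1ccccc1Cl` gives 11 nM. Compound 3 thus holds the second highest of the three numbers; its value and that of compound 1 lie within the scatter of each other, whereas the gap to compound 2 is beyond it, as a 3.4-fold lower number from compound 2 to compound 3 (0.53 log units; beyond the scatter) shows. The other measured steps, a 4.1-fold higher number from compound 1 to compound 2 (0.61 log units; beyond the scatter) and a 1.2-fold higher number from compound 1 to compound 3 (0.09 log units; within the scatter), also concern the aryl group on the saturated ring carbon, and none of them exceeds a modest size.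

Compound 4 `O=C(C(Nc1cccc(F)c1)c1ccc(C(F)(F)F)cc1)N1CCCC1c1ccccc1Cl` differs from compound 3 elsewhere: 3-fluorophenyl in place of 2-fluorophenyl on an amine nitrogen. Going by the values given here, no measured pair alters the group on this amine nitrogen, so there is no direct precedent. Among the compounds with values here, the only guide is that shifting a single halogen around an aromatic ring has moved this assay by modest amounts or not at all. The step from compound 3 to compound 4 is therefore expected to be small and its direction uncertain, with a 1.8-fold higher number from compound 3 to compound 4 (0.26 log units; within the scatter) as the estimate. Compound 4 is expected to give 20 nM, within a range from 6 nM to 70 nM.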

Compound 4, half-maximal inhibitory concentration: 138 nM
The estimate for compound 4 lay 6.9-fold (0.84 log units) below the measured number, and the stated range ends below it.
By their numbers in this assay, from the lowest: compounds 1 and 3 (each within the scatter of the next); then compound 2; then compound 4.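

In this assay, going by these compounds alone, the group on the amine nitrogen proves far more sensitive to the place of a single fluorine than the earlier compounds suggested: 3-fluorophenyl in place of 2-fluorophenyl gives a large step (a 13-fold higher number from compound 3 to compound 4 (1.10 log units; beyond the scatter)), whereas moving a fluorine on the aryl group of the saturated ring carbon gave only a modest one (a 4.1-fold higher number from compound 1 to compound 2 (0.61 log units; beyond the scatter)). The two groups have the same atoms and the same counts of donors and acceptors, so this large change comes with nothing more than a new place for the fluorine on the ring. No available evidence bears on what lies behind this difference.

The compounds shown leave open whether 2-fluorophenyl on the amine nitrogen is specifically favoured, since a plain phenyl, a 4-fluorophenyl or a 2-chlorophenyl at this nitrogen would be needed to tell whether such compounds stand nearer to compound 3 or to compound 4. They also leave open whether the same exchange would cost as much with another aryl group on the saturated ring carbon, such as the 3-fluorophenyl of compound 1.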